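Swapping 4-Chlorophenyl for Pyridin-3-yl on Compound 1

A few compounds are considered here, and "the series" means these few. Any claim that something is new, unique, unknown or untested is made for them only; others in the source may bear on it.

Compound 1 `O=C(N/N=C/c1ccc(Cl)cc1)c1cccnc1Nc1cccc(C(F)(F)F)c1` was tested in a functional assay on the whole organism (strain Wistar) for inhibition, with Rattus norvegicus as the target, read by paw edema, with a stated time of 3 h, at a dose of 10 mg/kg by the intraperitoneal route (a higher number here means more inhibition at the dose given (going by the name of the read-out), a lower number less inhibition), and gave 48.5%. Going by the values given here, of the three numbers measured so far it stands second highest. Its nearest neighbour is compound 2 `O=C(N/N=C/c1cccc(O)c1)c1cccnc1Nc1cccc(C(F)(F)F)c1`, which in this assay gave 49%; the step of a number 0.5 percentage points higher from compound 1 to compound 2 (within the scatter) separates the two. Furthest from it lies compound 3 `COc1ccc(/C=N/NC(=O)c2cccnc2Nc2cccc(C(F)(F)F)c2)c(OC)c1`, which in this assay gave 24.1%; the step of a number 24.4 percentage points lower from compound 1 to compound 3 (beyond the scatter) is clearly outside the usual spread. Compound 4 `O=C(N/N=C/c1cccnc1)c1cccnc1Nc1cccc(C(F)(F)F)c1` has not yet been measured. It differs from compound 1 in a single place: pyridin-3-yl in place of 4-chlorophenyl on a carbon with a double bond to nitrogen. Among the compounds with values here, two measured steps bear on this very position, since both compound 2 and compound 3 also vary the group on the carbon with a double bond to nitrogen. One of them, a number 0.5 percentage points higher from compound 1 to compound 2 (within the scatter), was flat; the other, a number 24.4 percentage points lower from compound 1 to compound 3 (beyond the scatter), was a modest loss. Within the data shown here, no measured step involves pyridin-3-yl itself, so the direction for compound 4 cannot be fixed from these data, and an outcome anywhere from unchanged to modestly lower seems plausible. Compound 4 is therefore expected to give about 42% in this assay, with a likely range from 25% to 58%. The expected step, a number 6.5 percentage points lower from compound 1 to compound 4 (within the scatter), would thus sit at the edge of the scatter.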

Compound 4, a percentage reported as inhibition, in the whole organism at one dose (the size of the read-out at that dose, not a potency): 52.4%
For compound 4 the middle estimate is 10.4 percentage points below the measured one, and the stated range covers the measured number.
By their numbers in this assay, from the lowest: compound 3; then compounds 1, 2 and 4 (each within the scatter of the next).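

With pyridin-3-yl on the carbon with a double bond to nitrogen, the read-out in this assay stays level with that of the 4-chlorophenyl compound (a number 3.9 percentage points higher from compound 1 to compound 4 (within the scatter)) and the 3-hydroxyphenyl compound (a number 3.4 percentage points higher from compound 2 to compound 4 (within the scatter)), so the earlier flat step now extends to a six-membered aromatic ring with a hetero atom, one that carries neither chlorine nor hydroxyl. Going by these compounds alone, compound 3 is the one compound that goes against this flat picture, and it now stands apart from all three others, with the new step to pyridin-3-yl (a number 28.3 percentage points higher from compound 3 to compound 4 (beyond the scatter)) matching in scale its two earlier gaps, so the loss belongs to 2,4-dimethoxyphenyl rather than to the replacement of 4-chlorophenyl as such. Nothing in the data given here explains why these groups fall as they do.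

The compounds shown leave open whether a single methoxy group on the ring would already bring the loss seen with compound 3, or whether it takes both. They also leave open whether pyridin-2-yl or pyridin-4-yl would read like pyridin-3-yl, and whether a ring carrying an amine or a carboxylic acid would stay at the same level.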